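This account rests on a few compounds, and the source may have more. Where it says the series, first, only, none or still open, it means among the compounds named here.

In a functional assay on SMMC-7721 cells (Homo sapiens) for cytotoxicity, read by MTT assay, with a stated time of 72 h (on this read-out higher numbers stand for weaker inhibition and lower numbers for stronger inhibition), compound 1 `O=C(CSC(=S)N[C@H]1CCOC1=O)Nc1ccccc1` reads > 128000 nM, which is a limit and not a number. Compound 2 `CCOC(=O)c1ccc(NC(=O)CSC(=S)N[C@H]2CCOC2=O)cc1` gives 64900 nM and compound 3 `CCCCc1ccc(NC(=O)CSC(=S)N[C@H]2CCOC2=O)cc1` gives 27300 nM, leaving compound 2 with the higher of the two actual numbers. Compound 4 `O=C(CSC(=S)N[C@H]1CCOC1=O)Nc1ccc(C(=O)/C=C/c2cccc(Cl)c2)cc1` carries 2-(3-chlorophenyl)ethenyl in place of ethoxy on a carbonyl carbon. Among the measured compounds shown here, no measured step changes this ethoxy group directly. The nearest guides are aromatic-carbon changes: an at least 1.9-fold lower number from compound 1 to compound 2 (0.29 log units; that floor lies within the scatter), an at least 4.6-fold lower number from compound 1 to compound 3 (0.67 log units; beyond the scatter) and a 2.4-fold lower number from compound 2 to compound 3 (0.38 log units; beyond the scatter). All point to lower numbers, so a modest lowering is expected in this assay, resting mainly on the last step. The expected step is a 3.2-fold lower number from compound 2 to compound 4 (0.51 log units; beyond the scatter). For compound 4 the estimated value is 20000 nM, with an expected range of 6000 nM to 64000 nM.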

Compound 4, half-maximal inhibitory concentration: 39100 nM
Estimate against measurement, compound 4: 2.0-fold (0.29 log units) below; the range from low to high includes it.
By their numbers in this assay, from the lowest: compounds 3, 4 and 2 (each within the scatter of the next, the first and the last beyond it). At a limit, above all of these: compound 1.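

At the carbonyl carbon, replacing ethoxy with the much larger 2-(3-chlorophenyl)ethenyl, which brings an aromatic ring and a double bond, gives a 1.7-fold lower number from compound 2 to compound 4 (0.22 log units; within the scatter) in this assay, so this exchange does not separate the two compounds. The earlier steps shown here changed groups on an aromatic carbon and left this carbonyl substituent untested. No available measurement bears on why this exchange leaves the read-out within the scatter.

On these data alone, whether an amine or a hydroxyl on the same carbonyl carbon would move the number remains open. So does whether the chlorine of 2-(3-chlorophenyl)ethenyl matters here.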